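From 4-methylpiperazin-1-yl to 2-(dimethylamino)ethyl

A few compounds are considered here, and "the series" means these few. Any claim that something is new, unique, unknown or untested is made for them only; others in the source may bear on it.

In a functional assay on HeLa cells (Homo sapiens) for antiproliferative activity, read by MTT assay, with a stated time of 48 h (a higher number here means a weaker inhibitor, a lower number a stronger inhibitor), compound 1 (`CCN(CC)CCn1c(N)c(-c2nc3ccccc3[nH]2)c2nc(C#N)c(C#N)nc21`) gives 11600 nM and compound 3 (`CN1CCN(CCCn2c(N)c(-c3nc4ccccc4[nH]3)c3nc(C#N)c(C#N)nc32)CC1`) gives 15600 nM, so these two values lie within the scatter of each other. Compound 2 (`N#Cc1nc2c(-c3nc4ccccc4[nH]3)c(N)n(CCN3CCCC3)c2nc1C#N`) reads > 50000 nM, which is a limit of the assay. Compound 4 (`CN(C)CCCCCn1c(N)c(-c2nc3ccccc3[nH]2)c2nc(C#N)c(C#N)nc21`) carries 2-(dimethylamino)ethyl in place of 4-methylpiperazin-1-yl, on a saturated chain carbon, three bonds along the chain from an aromatic nitrogen: 2-(dimethylamino)ethyl in place of 4-methylpiperazin-1-yl on a saturated chain carbon, three bonds along the chain from an aromatic nitrogen. The closest guide is a 1.3-fold higher number from compound 1 to compound 3 (0.13 log units; within the scatter), whereas an at least 4.3-fold higher number from compound 1 to compound 2 (0.63 log units; beyond the scatter) and an at least 3.2-fold lower number from compound 2 to compound 3 (0.50 log units; beyond the scatter) both rest on that limit. On this evidence, no step beyond the scatter is expected in this assay. The expected step is a 1.3-fold lower number from compound 3 to compound 4 (0.11 log units; within the scatter). For compound 4 the estimated value is 12000 nM, with an expected range of 4000 nM to 35000 nM.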

Compound 4, half-maximal inhibitory concentration: 10800 nM
Beside the measured number, compound 4's estimate is 1.1-fold (0.05 log units) above it; low and high end bracket the measured number.
By their numbers in this assay, from the lowest: compounds 4, 1 and 3 (each within the scatter of the next). At a limit, above all of these: compound 2.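

In this assay, the open-chain 2-(dimethylamino)ethyl takes the place of the ring of 4-methylpiperazin-1-yl with no step beyond the scatter (a 1.4-fold lower number from compound 3 to compound 4 (0.16 log units; within the scatter)), so at this position a ring is not needed to keep the reading of compound 3. Compound 4 also stays level with compound 1 (a 1.1-fold lower number from compound 1 to compound 4 (0.03 log units; within the scatter)), which leaves compound 2 as the one exception among the four. Among these compounds, only one of these steps is large (an at least 4.6-fold lower number from compound 2 to compound 4 (0.66 log units; beyond the scatter)), and it rests on a limit of the assay: the limit of > 50000 nM in this assay, at which 1 of the 4 values shown sits.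

On these data alone, whether a chain ending in morpholin-4-yl or in a primary amine would stay level with compounds 1, 3 and 4 remains open. So does whether a shorter chain carrying dimethylamino would do so.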